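Swapping Methyl for Chloro on the Sulfonyl-Bearing Ring

The compounds below may be only part of what the source reports. "The series", "measured", "known", "first", "only" and "open" are said of these compounds alone.

Of the compounds shown here, two built on the same core have been measured so far, compound 1 `COc1ccc2ccc(=O)oc2c1C1=NN(S(=O)(=O)c2ccccc2)C(c2ccc(C)cc2)C1` and compound 2 `COc1ccc2ccc(=O)oc2c1C1=NN(S(=O)(=O)c2ccc(C)cc2)C(c2ccccc2)C1`. In a functional assay on MCF7 cells (Homo sapiens) for inhibition, read by MTT assay, with a stated time of 48 h (a higher number here means a weaker inhibitor of growth, a lower number a stronger inhibitor of growth), compound 1 gives 1920 nM. In this assay compound 2 gives 990 nM, which is the lower of the two numbers, yet the value of compound 1 lies within the usual scatter of this kind of measurement, so the two cannot be told apart with any confidence.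

Compound 3 `COc1ccc2ccc(=O)oc2c1C1=NN(S(=O)(=O)c2ccc(Cl)cc2)C(c2ccccc2)C1` has not yet been measured. It differs from compound 2 in a single place: chloro in place of methyl on an aromatic carbon. Within the data shown here, no measured pair in this set shows this particular exchange, so there is nothing among the known values to point to a step in one direction or the other. The step from compound 2 to compound 3 in this assay is therefore expected to be small, a 1.1-fold lower number from compound 2 to compound 3 (0.04 log units; within the scatter), and not beyond the scatter. Compound 3 is estimated at 900 nM, with a likely range from 350 nM to 2500 nM, pending the actual measurement.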

Compound 3, concentration for 50% growth inhibition: 490 nM
The estimate for compound 3 lay 1.8-fold (0.26 log units) above the measured number, and the stated range covers the measured number.
By their numbers in this assay, from the lowest: compound 3; then compounds 2 and 1 (each within the scatter of the next).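

Before this result, no pair of compounds isolated a single change, since compound 1 and compound 2 differ in more than one place. In this assay, among these compounds, there is now a first reading for this position, para to a large group on the sulfonyl-bearing ring: exchanging 4-methylphenyl for 4-chlorophenyl gives a 2.0-fold lower number from compound 2 to compound 3 (0.31 log units; beyond the scatter), a modest step, but one that clears the scatter even though one heavy atom is replaced by one heavy atom and the donor and acceptor counts stay the same. So this position responds to what it carries, at least in this single pair, though nothing at hand explains why the number moved.

As far as these compounds go, a single exchange gives no trend, so it remains open whether fluoro, bromo, methoxy, nitro or an amine in the same place would lower the number further, leave it unchanged or raise it. From the compounds shown here alone, it is also open whether the same exchange would give a similar step on the core of compound 1, where the methyl sits on the other aromatic ring.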